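The source may report more compounds than this note shows. Statements on the series, on what has been measured and on what is new or still open speak of the compounds shown alone.

Among the compounds with values here, in an ADME assay on Vero cells (Chlorocebus sabaeus) for cytotoxicity, read by fluorescence and resazurin assay, with a stated time of 3 days (on this read-out lower numbers stand for higher toxicity in this test and higher numbers for lower toxicity in this test), only two compounds have numbers so far. Compound 1 `CCOC(=O)C[C@H]([C@H]1O[C@@H]2OC(C)(C)O[C@@H]2[C@H]1OCc1ccccc1)n1cnc2c(NCc3ccccc3)ncnc21` gives 53300 nM, while compound 2 `CC1(C)O[C@H]2O[C@H]([C@H](CCO)n3cnc4c(N)ncnc43)[C@@H](OCc3ccccc3)[C@H]2O1` gives 148000 nM. Compound 2 therefore has the higher of the two numbers, which means lower toxicity in this test, and the gap between them lies beyond the usual scatter.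

Compound 3 `CC1(C)O[C@H]2O[C@H]([C@H](CCO)n3cnc4c(N)ncnc43)[C@H](OCc3ccccc3)[C@H]2O1` has not yet been measured, and it is a very close relative of compound 2: the two compounds have the same atoms and bonds and differ only in configuration as drawn: 1 of 5 stereo elements differ; a stereocentre at a saturated ring carbon is drawn R in compound 2 and S in compound 3. The two compounds have the same atoms and bonds, and a stereocentre at a saturated ring carbon is drawn R in compound 2 and S in compound 3.

Within the data shown here, no measured pair differs in one place only, so the data give no direct guide to the effect of such a change. The starting expectation is therefore modest. In this assay, the expected 1.1-fold lower number from compound 2 to compound 3 (0.06 log units; within the scatter) stays within the scatter, with no firm direction. For compound 3 the estimated value is 130000 nM, with an expected range from 60000 nM to 280000 nM.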

Compound 3, half-maximal cytotoxic concentration: 97100 nM
Beside the measured number, compound 3's estimate is 1.3-fold (0.13 log units) above it; the range from low to high includes it.
By their numbers in this assay, from the lowest: compounds 1, 3 and 2 (each within the scatter of the next, the first and the last beyond it).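

Within the data shown here, this is the first pair that differs in one place only, so the effect of a single change can now be read directly. In this assay, changing a stereocentre at a saturated ring carbon from R to S gives a 1.5-fold lower number from compound 2 to compound 3 (0.18 log units; within the scatter) and leaves no firm direction, so in this test compound 2 and compound 3 cannot be told apart, and at this position the drawn configuration shows no clear effect on the number. The comparison is a clean one, with nothing else in the structures to confuse the reading: the fact that compounds 2 and 3 differ only in the configuration as drawn.

Among these compounds, the other four stereo elements have no such pair here, so this single result says nothing about whether changing any of them would give an equally small step. From the compounds shown here alone, it also remains open whether the configuration at this ring carbon would matter as little if the hydroxyl group on the chain of compound 2 and compound 3 were replaced by a carboxylic acid or an amine, or if the benzyl ether were replaced by a plain hydroxyl group.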